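The source may hold more compounds than are shown below. What is called first, only, known or untested is meant among the compounds shown, and "the series" means these compounds.

Measured so far in a functional assay on L1210 cells (Mus musculus) for cytotoxicity, with a stated time of 48 h; on this read-out lower numbers stand for stronger inhibition and higher numbers for weaker inhibition:
- Compound 1 `C=C(Br)C(=O)Nc1cc(C(=O)Nc2ccccc2)n(C)c1` gives 43 nM
- Compound 2 `C=C(Br)C(=O)Nc1ccccc1` gives 36.8 nM

Only these two compounds have been measured, and their values lie within the usual scatter of each other. Compound 2 therefore stands level with compound 1 on the numbers available, and neither can be ranked above the other.

The next compound to be tested is compound 3 `C=C(Br)C(=O)Nc1ccc(F)cc1`, which differs from compound 2 in one place: fluoro in place of hydrogen on an aromatic carbon. In words, fluoro takes the place of hydrogen on an aromatic carbon.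

Among the measured compounds shown here, no measured step shows what such a change does in this assay, so the expectation has little to rest on. Its starting point is compound 2 at 36.8 nM, and no step beyond the scatter is expected, in either direction. The estimated change is a 1.1-fold lower number from compound 2 to compound 3 (0.02 log units; within the scatter) and would be too small to read as a real difference. For compound 3 the expected value is 35 nM, with an estimated range from 14 nM to 85 nM.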

Compound 3, half-maximal inhibitory concentration: 58.6 nM
Estimate against measurement, compound 3: 1.7-fold (0.22 log units) below, within the range that was stated.
By their numbers in this assay, from the lowest: compounds 2, 1 and 3 (each within the scatter of the next).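

In this assay, putting fluoro in place of hydrogen on an aromatic carbon of the six-membered ring, para to a group of 6 heavy atoms, gives a 1.6-fold higher number from compound 2 to compound 3 (0.20 log units; within the scatter). Among the compounds shown here, this is the first measured step on this ring, and it shows that this place can take a single fluorine atom without a difference that can be told from the scatter of repeated measurements, so the two compounds count as level on this read-out. Nothing available explains the result or ties it to any property of the fluoro group.

As far as these compounds go, one small atom at one place says little about how much this position tolerates, so it remains open whether a larger or differently built group at the same place, such as methoxy, an amine or a carboxylic acid, would also leave the number within the scatter. Also open, from the compounds shown here alone, are how fluoro would behave on the other carbons of this ring and whether the same exchange would read the same way on the longer scaffold of compound 1.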